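The compounds below may be only part of what the source reports. "The series", "measured", "known", "first", "only" and "open" are said of these compounds alone.

Measured compounds:
compound 1, `COC(=O)c1ccc(-c2cnc(C(O)CCc3ccc(-c4ccccc4)cc3)o2)nc1`, with 1100 nM;
compound 2, `COC(=O)c1cc(-c2cnc(C(=O)CCc3ccc(-c4ccccc4)cc3)o2)ccn1`, with 1.5 nM.

For the measured compounds named here, in an assay for inhibition of Fatty-acid amide hydrolase 1 (Rattus norvegicus) (on this read-out lower numbers stand for stronger inhibition and higher numbers for weaker inhibition), compound 2 stands lowest of the two numbers; compound 1 gives 1100 nM, a higher number than compound 2 gives with 1.5 nM, and the two compounds differ in more than one place, so no single step is drawn between them. Compound 3, `COC(=O)c1cnc(C(=O)CCc2ccc(-c3ccccc3)cc2)o1`, is not yet measured. Compared with compound 2 it carries methoxycarbonyl in place of 2-(methoxycarbonyl)pyridin-4-yl on an aromatic carbon. The change removes most of one end of the molecule; the account expects a sizeable step upward in this assay, beyond the scatter, from compound 2 to compound 3 of a 27-fold higher number from compound 2 to compound 3 (1.43 log units; beyond the scatter). For compound 3 the estimate is 40 nM, between 5 nM and 400 nM.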

Compound 3, inhibition constant: 1.5 nM
Estimate against measurement, compound 3: 27-fold (1.43 log units) above, and the stated range ends above it.
By their numbers in this assay, from the lowest: compounds 2 and 3 (each within the scatter of the next); then compound 1.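

In this assay, methoxycarbonyl in place of 2-(methoxycarbonyl)pyridin-4-yl on the aromatic carbon next to the ring oxygen gives no change at the digits printed from compound 2 to compound 3 (within the scatter), so the six-membered aromatic ring can leave this position without a change that can be read. The smaller methoxycarbonyl is enough here to keep the number within the scatter. The data offer no measured explanation for this result. The compounds shown leave open how a carboxylic acid, a primary amide or a plain hydrogen at this position would read. They also leave open what a hydroxyl in place of the carbonyl in compound 3 would do.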